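This account rests on a few compounds, and the source may have more. Where it says the series, first, only, none or still open, it means among the compounds named here.

Working notes on the series. Three compounds have numbers in a functional assay on V79 cells (Cricetulus griseus) for cytotoxicity, read by colony formation; a lower number here means a stronger inhibitor, a higher number a weaker inhibitor. Compound 1 `O=C(O)c1cn(C2CC2)c2c(C(F)(F)F)c(N3CCCC3)c(F)cc2c1=O` gives 280 ug/mL. Compound 2 `CNCC1(C)CCN(c2cc3c(cc2F)c(=O)c(C(=O)O)cn3C2CC2)C1` gives 205 ug/mL. Compound 3 `CNCC1(C)CCN(c2c(F)cc3c(=O)c(C(=O)O)cn(C4CC4)c3c2C(F)(F)F)C1` gives 230 ug/mL. On these three numbers compound 3 sits between the other two, and both gaps are within the scatter: the step of a 1.2-fold lower number from compound 1 to compound 3 (0.09 log units; within the scatter) and the step of a 1.1-fold higher number from compound 2 to compound 3 (0.05 log units; within the scatter) are each too small to read as a real shift. The whole set so far spans no more than the repeat variation of this assay.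

Compound 4 `CC1(N)CCN(c2c(F)cc3c(=O)c(C(=O)O)cn(C4CC4)c3c2C(F)(F)F)C1` is the next member, not yet measured. It differs from compound 3 in one place: amino in place of (methylamino)methyl on a saturated ring carbon. Neither measured step bears directly on this change. The step from compound 1 to compound 3 replaced the whole pyrrolidin-1-yl, and the step from compound 2 to compound 3 acted on an aromatic carbon; the present change sits on a saturated ring carbon of the five-membered non-aromatic ring with 1 nitrogen and exchanges (methylamino)methyl for amino. Both known steps were within the scatter, and nothing in the series suggests this smaller exchange should move the number further. The expectation is therefore no step beyond the scatter, no change at the digits printed from compound 3 to compound 4 (within the scatter). Compound 4 is expected at 230 ug/mL, within 130 ug/mL to 400 ug/mL.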

Compound 4, half-maximal inhibitory concentration: 110 ug/mL
The estimate for compound 4 lay 2.1-fold (0.32 log units) above the measured number, outside the stated range (below it).
By their numbers in this assay, from the lowest: compounds 4, 2, 3 and 1 (each within the scatter of the next, the first and the last beyond it).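

In this assay, among the compounds shown here, this saturated ring carbon is the first place where a change moves the number beyond the scatter: amino in place of (methylamino)methyl gives a 2.1-fold lower number from compound 3 to compound 4 (0.32 log units; beyond the scatter), a modest step. The larger exchange of the whole pyrrolidin-1-yl now reads differently according to what the new ring carries, with 3-methyl-3-((methylamino)methyl)pyrrolidin-1-yl giving a 1.2-fold lower number from compound 1 to compound 3 (0.09 log units; within the scatter) and 3-amino-3-methylpyrrolidin-1-yl giving a 2.5-fold lower number from compound 1 to compound 4 (0.41 log units; beyond the scatter), so on these compounds that exchange has a readable result only with the amino group present. No measurement at hand accounts for the step.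

The compounds shown leave open whether the step follows the shorter chain or the change at the nitrogen, a question that aminomethyl or methylamino on the same ring carbon would separate. They also leave open whether the step from (methylamino)methyl to amino holds with hydrogen in place of trifluoromethyl on the aromatic carbon, and whether it holds in any assay other than this assay.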